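Isobutyl to benzyl on a series at its limit

The source may hold more compounds than are shown below. What is called first, only, known or untested is meant among the compounds shown, and "the series" means these compounds.

In a functional assay on MDA-MB-468 cells (Homo sapiens) for antiproliferative activity, read by MTT assay, with a stated time of 72 h (a lower number here means a stronger inhibitor, a higher number a weaker inhibitor), three compounds with a shared core have been measured. Compound 1 `CCCn1ccnc1-c1cc(OC)c(OC)c(OC)c1` gives > 100000 nM as a limit of the assay. Compound 2 `COc1cc(-c2nccn2C(C)C)cc(OC)c1OC` gives > 100000 nM as a limit too. Compound 3 `COc1cc(-c2nccn2CC(C)C)cc(OC)c1OC` gives > 100000 nM as a limit as well, so no actual number is known for it.

Compound 4 `COc1cc(-c2nccn2Cc2ccccc2)cc(OC)c1OC` differs from compound 3 by phenyl in place of isopropyl on a saturated chain carbon bound to an aromatic nitrogen, which also reads as isobutyl to benzyl. For the measured compounds named here, three measured steps bear on this change: (a step that the two limits leave unreadable from compound 1 to compound 2), (a step that the two limits leave unreadable from compound 1 to compound 3) and (a step that the two limits leave unreadable from compound 2 to compound 3). None has a readable size, and all three swap one ringless chain for another.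

In this assay at best a small step towards stronger inhibition is expected (an at least 1.2-fold lower number from compound 3 to compound 4 (0.09 log units; that floor lies within the scatter)), and another result at the limit is quite possible. For compound 4 the estimated value is 80000 nM with an expected range from 20000 nM to 200000 nM in this measurement.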

Compound 4, half-maximal inhibitory concentration: > 100000 nM
Compound 4 was reported as a limit; the forecaster's own chance of this, stated with the estimate: 60%; middle value at least 1.2-fold (0.09 log units) from the limit.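

Compound 4 also gives only a limit, so its steps from compound 1, compound 2 and compound 3 cannot be read: the limit of > 100000 nM in this assay, at which 4 of the 4 values shown sit. From the compounds shown here alone, how strongly any of these four compounds inhibits, and whether benzyl differs from the ringless chains, stays open.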